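Sulfonyl variants in a cytotoxicity screen

The compounds below may be only part of what the source reports. "The series", "measured", "known", "first", "only" and "open" are said of these compounds alone.

Of the compounds shown here, two have been measured in an ADME assay on PC-3 cells (Homo sapiens) for cytotoxicity, read by WST assay, tested at 100 uM; a lower number here means less inhibition, a higher number more inhibition at the concentration tested (going by the name of the read-out). Compound 1 `CC(C)(C)OC(=O)c1cccc(NC(=O)C2CCCN(C(=O)c3cc(C(F)(F)F)cc(C(F)(F)F)c3)C2)c1` gives 0% in this assay. Compound 2 `CS(=O)(=O)Nc1cccc(C(=O)N2CCCC(C(=O)Nc3ccc(Cl)cc3)C2)c1` gives 3% in this assay; on the two numbers available it stands highest, but its gap to compound 1 lies within the scatter, so the two values show no separation that can be read as real. Among the measured compounds shown here, no pair of measured compounds differs in only one place, so no single step is available.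

Compound 3 `CCN(CC)S(=O)(=O)c1cccc(C(=O)N2CCCC(C(=O)Nc3ccc(Cl)cc3)C2)c1` differs from compound 2 in one place: diethylsulfamoyl in place of methanesulfonamido on an aromatic carbon. Both measured values sit at the bottom of the scale, and nothing in the data speaks for a move away from it. The expected step is a number 2 percentage points higher from compound 2 to compound 3 (within the scatter), which is nothing beyond the scatter. Compound 3 is estimated to give about 5% in this assay, within a range from 0% to 20%.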

Compound 3, a percentage reported as inhibition, at one concentration (the size of the read-out at that concentration, not a potency): 0%
Beside the measured number, compound 3's estimate is 5 percentage points above it; the range from low to high includes it.
By their numbers in this assay, from the lowest: compounds 1, 3 and 2 (each within the scatter of the next).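

In this assay, diethylsulfamoyl in place of methanesulfonamido on this aromatic carbon, meta to a large group, gives a number 3 percentage points lower from compound 2 to compound 3 (within the scatter). Among the compounds shown here, this is the first single-place comparison, and at this position it shows no separation between the two groups, although the change adds carbon atoms and removes the hydrogen-bond donor. Nothing available bears on what lies behind this result.

The comparison covers only these two groups, both sulfur-containing and both with values at the bottom of the scale, so it does not show whether this position can move the read-out at all. From the compounds shown here alone, whether a carboxylic acid or an amine on this aromatic carbon would give a value separated from compound 2 remains open.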